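Replacing cyclohexyl with cyclopentyloxy in a growth inhibitor

A few compounds are considered here, and "the series" means these few. Any claim that something is new, unique, unknown or untested is made for them only; others in the source may bear on it.

Measured so far in a functional assay on HT-29 cells (Homo sapiens) for inhibition, read by sulforhodamine B assay, with a stated time of 48 h; on this read-out lower numbers stand for stronger inhibition of growth and higher numbers for weaker inhibition of growth:
Compound 1 `c1ccc2cc(NC3=NCCO3)ccc2c1` gives 2000 nM
Compound 2 `c1cc(C2CCCCC2)ccc1NC1=NCCO1` gives 12800 nM
Compound 3 `c1ccc(-c2ccc(NC3=NCCO3)cc2)cc1` gives 5800 nM

Among these three, compound 2 has the highest number and so shows the weakest inhibition of growth in this assay. Compound 3 lies nearest to it and compound 1 furthest away.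

Compound 4 `c1cc(OC2CCCC2)ccc1NC1=NCCO1` has not yet been measured. It shares its core with compound 2 and differs in one group: cyclopentyloxy in place of cyclohexyl on an aromatic carbon and, in words, cyclopentyloxy in place of cyclohexyl on an aromatic carbon.

Among the compounds with values here, only one measured step bears on this change. It is a 2.2-fold lower number from compound 2 to compound 3 (0.34 log units; beyond the scatter), with phenyl in place of cyclohexyl on an aromatic carbon. That step is modest but beyond the scatter, and it shows only that replacing cyclohexyl at this place can lower the number. Within the data shown here, no measured compound carries cyclopentyloxy, so the guide is a loose one. A modest step toward a lower number in this assay is therefore expected, of about the same size as that single step. The estimated step is a 2.1-fold lower number from compound 2 to compound 4 (0.33 log units; beyond the scatter) (an expectation resting on one measured replacement). Compound 4 is expected at 6000 nM, within an estimated range from 2500 nM to 14000 nM.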

Compound 4, concentration for 50% growth inhibition: 16100 nM
Beside the measured number, compound 4's estimate is 2.7-fold (0.43 log units) below it, and the stated range ends below it.
By their numbers in this assay, from the lowest: compound 1; then compound 3; then compounds 2 and 4 (each within the scatter of the next).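

In this assay, cyclopentyloxy in place of cyclohexyl on this aromatic carbon gives a 1.3-fold higher number from compound 2 to compound 4 (0.10 log units; within the scatter), so a swap that brings in an oxygen, a hydrogen-bond acceptor and a five-membered ring in place of a six-membered one produces no difference beyond the scatter. The same group set against phenyl gives a 2.8-fold higher number from compound 3 to compound 4 (0.44 log units; beyond the scatter), which shows that the earlier lower number at this position does not follow from replacing cyclohexyl as such: among these three compounds, only compound 3, with its phenyl group, stands apart, while compound 2 and compound 4, each with a non-aromatic ring, stay together. No measurement available here accounts for why phenyl stands apart from the other two groups.

The compounds shown leave open whether the oxygen and the ring size each matter on their own, as both differ at once in this step, and a cyclopentyl or a cyclohexyloxy group at this place would separate the two. They also leave open how a group of a different kind on this aromatic carbon, such as an amine or a carboxylic acid, would read in this assay.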